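The compounds below may be only part of what the source reports. "The series", "measured", "known", "first", "only" and "open" are said of these compounds alone.

Working notes on the series. The read-out throughout is a functional assay on CHO-K1 cells for antagonist activity at transient receptor potential cation channel subfamily V member 1 (Homo sapiens), read by FLIPR; on this read-out higher numbers stand for weaker inhibition and lower numbers for stronger inhibition. For the measured compounds named here, compound 1 `Cc1ccc(Nc2nc(C(F)(F)F)ccc2CNC(=O)C(C)c2ccc(NS(C)(=O)=O)c(F)c2)cc1C` gives 39.3 nM in this assay, the highest of the three numbers measured so far. Compound 2 `CC(C(=O)NCc1ccc(C(F)(F)F)nc1N1CCC(C)(C)CC1)c1ccc(NS(C)(=O)=O)c(F)c1` gives 0.3 nM, and compound 3 `CC(C(=O)NCc1ccc(C(F)(F)F)nc1N1CCC(C(=O)c2ccc(F)cc2)CC1)c1ccc(NS(C)(=O)=O)c(F)c1` gives 3.9 nM; the two values of compound 1 and compound 3 stand a full order apart, with compound 3 the lower.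

Compound 4 `CC(=O)OC1CCN(c2nc(C(F)(F)F)ccc2CNC(=O)C(C)c2ccc(NS(C)(=O)=O)c(F)c2)CC1` has not been measured yet. Against compound 1 the change is 4-acetoxypiperidin-1-yl in place of (3,4-dimethylphenyl)amino on an aromatic carbon. Going by the values given here, the one step that bears on it directly is a 130-fold lower number from compound 1 to compound 2 (2.12 log units; beyond the scatter), where the same (3,4-dimethylphenyl)amino group gave way to 4,4-dimethylpiperidin-1-yl. Compound 3 carries a differently decorated group in the same position and sits well below compound 1 yet clearly above compound 2, so the benefit of leaving the (3,4-dimethylphenyl)amino group is not confined to one replacement, but its size varies with what enters.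

For compound 4 a large step downward in this assay is therefore expected, a 20-fold lower number from compound 1 to compound 4 (1.29 log units; beyond the scatter), most likely landing between the values of compound 2 and compound 3. The estimate for compound 4 is 2 nM, with a range from 0.4 nM to 10 nM.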

Compound 4, inhibition constant: 4 nM
Beside the measured number, compound 4's estimate is 2.0-fold (0.30 log units) below it; measured number inside the range.
By their numbers in this assay, from the lowest: compound 2; then compounds 3 and 4 (each within the scatter of the next); then compound 1.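

Moving from the (3,4-dimethylphenyl)amino group to 4-acetoxypiperidin-1-yl in this assay gives a 9.8-fold lower number from compound 1 to compound 4 (0.99 log units; beyond the scatter), so a second substituted piperidin-1-yl group at this position, on the aromatic carbon next to the ring nitrogen, now gives a number beyond the scatter below that of compound 1, and this one brings an ester in place of the two methyl groups of compound 2. What sits on the piperidine ring also matters here, as exchanging 4,4-dimethyl for 4-acetoxy gives a 13-fold higher number from compound 2 to compound 4 (1.12 log units; beyond the scatter), a step in the opposite direction that gives back part of the gain. Acetoxy and (4-fluorophenyl)carbonyl on the same saturated ring carbon cannot be told apart in this assay, with a 1.0-fold higher number from compound 3 to compound 4 (0.01 log units; within the scatter), so these two quite different groups give the same result at this position.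

The compounds shown leave open how an unsubstituted piperidin-1-yl, a 4-hydroxypiperidin-1-yl or a 4-aminopiperidin-1-yl group would stand against the 4,4-dimethylpiperidin-1-yl group of compound 2. Nothing measured here gives a reason for any of these steps.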